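Dihydrofuranyl amide in place of methylfuranyl: solubility note

The source may hold more compounds than are shown below. What is called first, only, known or untested is meant among the compounds shown, and "the series" means these compounds.

Compound 1 `Cc1occc1C(=O)N1CCC(NC(=O)Nc2ccc(OC(F)(F)F)cc2)CC1` gives 8.6 ug/mL in a physicochemical assay for solubility, read by mass spectrometry, in phosphate buffer, with a stated time of 24 h, at pH 7.4; a higher number here means a more soluble compound, a lower number a less soluble compound. Compound 3 `O=C(Nc1ccc(C(F)(F)F)cc1)NC1CCN(C(=O)C2CCOC2)CC1` gives 9.6 ug/mL in this assay, within the scatter of compound 1. Compound 2 `Cc1ccoc1C(=O)N1CCC(NC(=O)Nc2ccc(C(F)(F)F)cc2)CC1` gives 0.8 ug/mL, so compound 1 stands far above compound 2 and is not separated from compound 3. Compound 4 `O=C(Nc1ccc(OC(F)(F)F)cc1)NC1CCN(C(=O)C2=COCC2)CC1` differs from compound 1 by a group of 5 heavy atoms (4 carbon, 1 oxygen; one five-membered non-aromatic ring with 1 hetero atom) in place of a group of 6 heavy atoms (5 carbon, 1 oxygen; one five-membered aromatic ring with 1 hetero atom), on a carbonyl carbon. Among the compounds with values here, the only single-place step recorded is a 12-fold higher number from compound 2 to compound 3 (1.08 log units; beyond the scatter), also an exchange of a five-membered aromatic ring for a non-aromatic one on a carbonyl carbon. Because a 12-fold higher number from compound 2 to compound 3 (1.08 log units; beyond the scatter) was large yet the entering ring of compound 4 retains one double bond, a smaller rise is expected, a 2.3-fold higher number from compound 1 to compound 4 (0.37 log units; beyond the scatter). For compound 4 the estimate in this assay is 20 ug/mL, ranging from 7 ug/mL to 55 ug/mL.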

Compound 4, solubility: 11 ug/mL
Beside the measured number, compound 4's estimate is 1.8-fold (0.26 log units) above it, within the range that was stated.
By their numbers in this assay, from the lowest: compound 2; then compounds 1, 3 and 4 (each within the scatter of the next).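

On this carbonyl carbon, in this assay, the exchange of 2-methylfuran-3-yl for the non-aromatic five-membered ring with one double bond gives a 1.3-fold higher number from compound 1 to compound 4 (0.11 log units; within the scatter), so this change leaves compounds 1 and 4 unseparated. The large step seen earlier, a 12-fold higher number from compound 2 to compound 3 (1.08 log units; beyond the scatter), therefore does not extend to every exchange of an aromatic ring for a non-aromatic one at this place. No available evidence bears on the reason for this result. As far as these compounds go, whether a group carrying an amine or a carboxylic acid on this carbonyl carbon would shift the number beyond the scatter remains open.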